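From furan-3-yl to 1-benzofuran-2-yl in a series at its limits

The compounds below may be only part of what the source reports. "The series", "measured", "known", "first", "only" and "open" are said of these compounds alone.

Measured in a functional assay on HL-60 cells (Homo sapiens) for antiproliferative activity, read by XTT assay, with a stated time of 72 h; a higher number here means a weaker inhibitor, a lower number a stronger inhibitor:
- compound 1 `CNc1ncnc2c1c(-c1cccs1)cn2[C@@H]1O[C@H](CO)[C@@H](O)[C@H]1O` gives > 20000 nM (a limit)
- compound 2 `COc1nc(N)nc2c1c(-c1cccs1)cn2[C@@H]1O[C@H](CO)[C@@H](O)[C@H]1O` gives > 20000 nM (a limit)
- compound 3 `Nc1nc2c(c(-c3ccoc3)cn2[C@@H]2O[C@H](CO)[C@@H](O)[C@H]2O)c(=O)[nH]1` gives > 15000 nM (a limit)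

Compound 3 has no measured number in this assay, only the limit > 15000 nM. Going by the values given here, the three results fall at two limits, the limit of > 15000 nM in this assay, at which 1 of the 3 values shown sits, and (the limit of > 20000 nM in this assay, at which 2 of the 3 values shown sit), so no measured step is available to calibrate the series.

The next compound is compound 4 `Nc1nc2c(c(-c3cc4ccccc4o3)cn2[C@@H]2O[C@H](CO)[C@@H](O)[C@H]2O)c(=O)[nH]1`. Going from compound 3 to compound 4, 1-benzofuran-2-yl replaces furan-3-yl on an aromatic carbon of a five-membered aromatic ring with 1 nitrogen (1-benzofuran-2-yl in place of furan-3-yl on an aromatic carbon).

In this assay, no step beyond the scatter is expected, and a limit is the most likely report. This expectation rests on compound 3, whose > 15000 nM is a limit. The expected size of the change is a step that the limit leaves unreadable from compound 3 to compound 4. For compound 4, the estimated half-maximal inhibitory concentration is 20000 nM, with an expected range of 5000 nM to 40000 nM.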

Compound 4, half-maximal inhibitory concentration: > 20000 nM
Compound 4 gave a limit, no number; the forecaster's own chance of this, stated with the estimate: 80%; the middle value lies on the limit itself.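

In this assay compound 3 gives > 15000 nM, a limit. Compound 4 gives > 20000 nM, also a limit, so no step can be read for 1-benzofuran-2-yl in place of furan-3-yl. The compounds shown leave open whether any of them has a measurable value in this assay.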